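Lactam ring size and solubility across two cores

The compounds below may be only part of what the source reports. "The series", "measured", "known", "first", "only" and "open" are said of these compounds alone.

Compound 1 `CC(=O)N1CCc2cc(-c3cccc4c3CCCC4)cc(N3CCCC3=O)c21` gives 271000 nM in a physicochemical assay for solubility, at pH 7.4; a higher number here means a more soluble compound, a lower number a less soluble compound. Compound 2 `CC(=O)N1CCc2cc(-c3cccc4c3CCCC4)cc(N3CCCCC3=O)c21` carries the change 2-oxopiperidin-1-yl in place of 2-oxopyrrolidin-1-yl on an aromatic carbon and gives 259000 nM in this assay; the step is a 1.0-fold lower number from compound 1 to compound 2 (0.02 log units; within the scatter). Compound 3 `O=C1CCCN1c1cnc(NCc2c(F)ccc3c2CCO3)c2cn[nH]c(=O)c12` gives 66000 nM in this assay, the lowest of the three numbers; the difference between its core and the core of compound 1 is not broken down here. Compound 4 `O=C1CCCCN1c1cnc(NCc2c(F)ccc3c2CCO3)c2cn[nH]c(=O)c12` is not yet measured and carries 2-oxopiperidin-1-yl in place of 2-oxopyrrolidin-1-yl on an aromatic carbon. This is the same kind of change as in compound 2, but the place differs: in compound 1 the ring is of carbon only and the group sits meta to a large group, while in compound 3 the ring holds 1 nitrogen, the group is two atoms from the ring nitrogen and para to a large group. Because a 1.0-fold lower number from compound 1 to compound 2 (0.02 log units; within the scatter) lay within the scatter, the step from compound 3 to compound 4 is expected to be no change at the digits printed from compound 3 to compound 4 (within the scatter) in this assay. Compound 4 is thus estimated at 66000 nM, between 33000 nM and 130000 nM.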

Compound 4, solubility: 18000 nM
Beside the measured number, compound 4's estimate is 3.7-fold (0.56 log units) above it, outside the stated range (below it).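

In this assay the change to 2-oxopiperidin-1-yl in place of 2-oxopyrrolidin-1-yl did not carry over between the two cores: a 1.0-fold lower number from compound 1 to compound 2 (0.02 log units; within the scatter) stays within the scatter, whereas a 3.7-fold lower number from compound 3 to compound 4 (0.56 log units; beyond the scatter) lies beyond it. A flat step on the core of compound 1 therefore says little about the same change on the core of compound 3, though two pairs give no general rule for the series. Nothing shown here accounts for the gap between the two steps.

From the compounds shown here alone, it remains open how a piperazine or a carboxylic acid in place of the lactam would read on the core of compound 3. A third core carrying both lactams would show which of the two steps is more typical.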